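Lengthening the Chain Beyond the Amine in a Weak Antiproliferative

This account rests on a few compounds, and the source may have more. Where it says the series, first, only, none or still open, it means among the compounds named here.

Compound 1 `CCCCNCCCCC(=O)Nc1ccc(/C(N)=N/O)cc1` and compound 2 `CCCCNCCC(=O)Nc1ccc(/C(N)=N/O)cc1` share one core and differ only in the length of the saturated chain that joins the amide carbonyl to the amine nitrogen. In a functional assay on HCT-116 cells (Homo sapiens) for antiproliferative activity, read by WST assay, with a stated time of 72 h (a higher number here means that more compound is needed for the effect, a lower number that less compound is needed), compound 1 gives 516000 nM, the highest of the two numbers, while compound 2 gives 153000 nM. Among the compounds with values here, the step of a 3.4-fold lower number from compound 1 to compound 2 (0.53 log units; beyond the scatter) is the only change with a known effect in this set.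

Compound 3 `CCCCCCNCCCCC(=O)Nc1ccc(/C(N)=N/O)cc1` keeps the longer chain of compound 1 and instead carries a different change: ethyl in place of hydrogen on a saturated chain carbon, four bonds along the chain from an amine nitrogen. Within the data shown here, this sits at another place than the shortening seen between compound 1 and compound 2, so that step does not bear on it directly, and no measured pair shows what adding carbons on that side of the amine nitrogen does. With no guide in this assay, the expectation is a step no larger than the usual scatter, a 1.3-fold lower number from compound 1 to compound 3 (0.11 log units; within the scatter). Compound 3 is thus estimated at 400000 nM, within a range of 150000 nM to 1000000 nM.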

Compound 3, half-maximal effective concentration: > 1000000 nM
Compound 3: only a limit was reported; the forecaster's own chance of this, stated with the estimate: 10%; at least 2.5-fold (0.39 log units) between middle value and limit.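

In this assay compound 3 gives > 1000000 nM, which is a limit of the assay and not a number: the limit of > 1000000 nM in this assay, at which 1 of the 3 values shown sits.

Even so, this is the first reading on the far side of the amine nitrogen, since the earlier pair changed only the chain running to the carbonyl. The ethyl in place of hydrogen gives an at least 1.9-fold higher number from compound 1 to compound 3 (0.28 log units; that floor lies within the scatter), and although that floor lies within the scatter, the change clearly brings no lower number of the kind seen with the shorter chain in a 3.4-fold lower number from compound 1 to compound 2 (0.53 log units; beyond the scatter).

From the compounds shown here alone, how far the true value of compound 3 lies past its limit stays open, so the full size of this step is unknown, and a single change on this side cannot show whether any substitution there would behave the same way. A methyl group or a phenyl ring in the same place, or the ethyl added to the shorter chain of compound 2, would be needed to tell whether this side of the amine nitrogen tolerates any change at all.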